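A few compounds are considered here, and "the series" means these few. Any claim that something is new, unique, unknown or untested is made for them only; others in the source may bear on it.

- Compound 1 `O=c1cc(I)n([C@@H]2O[C@H](CO)[C@@H](O)[C@H]2O)c(=O)[nH]1` in a functional assay on OCI-Ly7 cells (Homo sapiens) for antiproliferative activity, read by WST assay, with a stated time of 3 days; on this read-out lower numbers stand for stronger inhibition and higher numbers for weaker inhibition: > 50000 nM, a limit
- Compound 2 `[N-]=[N+]=Nc1cc(=O)[nH]c(=O)n1[C@@H]1O[C@H](CO)[C@@H](O)[C@H]1O` in this assay: > 50000 nM, a limit
- Compound 3 `CN(C)c1cc(=O)[nH]c(=O)n1[C@@H]1O[C@H](CO)[C@@H](O)[C@H]1O` in this assay: > 50000 nM, a limit

Compound 3 has no exact number in this assay, only a limit. The same is true of the other two compounds: the limit of > 50000 nM in this assay, at which 3 of the 3 values shown sit.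

The next compound is compound 4 `O=c1cc(NO)n([C@@H]2O[C@H](CO)[C@@H](O)[C@H]2O)c(=O)[nH]1`. Its change from compound 3 is hydroxyamino in place of dimethylamino on an aromatic carbon. In words, hydroxyamino takes the place of dimethylamino on an aromatic carbon, next to the ring nitrogen.

The measured steps that bear on this change also exchange the group at this place. They are a step that the two limits leave unreadable from compound 1 to compound 3 and a step that the two limits leave unreadable from compound 2 to compound 3, along with a step that the two limits leave unreadable from compound 1 to compound 2. None of them has a readable size, so none supplies a number to carry over to compound 4. They show only that iodo, azido and dimethylamino all end at the same limit. Hydroxyamino has not been tested among these compounds, so a measurable value cannot be ruled out, and any such value would be expected to lie on the side of stronger inhibition. The likeliest result is another limit, with no step beyond the scatter.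

The expected step is a number no higher from compound 3 to compound 4 (the limit leaves the size open).

Compound 4 is estimated at 50000 nM, with an expected range from 10000 nM to 100000 nM.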

Compound 4, half-maximal inhibitory concentration: > 50000 nM
Compound 4: no number, only a limit; the forecaster's own chance of this, stated with the estimate: 70%; the middle value sits exactly at the limit.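

In this assay, for the compounds shown here, compound 4 gives > 50000 nM, which is a limit and not a number, so no step between compound 4 and compound 1, compound 2 or compound 3 can be read. The compounds shown leave open whether they differ at all in strength, and whether any group at this place would give a measurable value: the limit of > 50000 nM in this assay, at which 4 of the 4 values shown sit.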